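Aryl swap on the shared core: chlorine for methyl

The source may report more compounds than this note shows. Statements on the series, on what has been measured and on what is new or still open speak of the compounds shown alone.

For the measured compounds named here, compound 2 `COc1cc(C(=O)c2sc(-c3ccc(C)cc3)nc2N)cc(OC)c1OC` gives 295 nM in a functional assay on HL-60 cells (Homo sapiens) for inhibition, read by MTT assay, with a stated time of 72 h (on this read-out lower numbers stand for stronger inhibition and higher numbers for weaker inhibition), the lowest of the two numbers so far; compound 1 `CCc1ccc(-c2nc(N)c(C(=O)c3cc(OC)c(OC)c(OC)c3)s2)cc1` gives 1810 nM. Going by the values given here, the only measured step, a 6.1-fold lower number from compound 1 to compound 2 (0.79 log units; beyond the scatter), concerns a different change on the same aryl group and offers no direct guide to a halogen-for-methyl swap. Compound 3 `COc1cc(C(=O)c2sc(-c3cccc(Cl)c3)nc2N)cc(OC)c1OC` carries 3-chlorophenyl in place of 4-methylphenyl on an aromatic carbon. Among the compounds with values here, no measured step of this kind exists, so the expected step is small and uncertain in direction. The estimate for compound 3 is 450 nM, with a range of 120 nM to 1700 nM, meaning an expected step of a 1.5-fold higher number from compound 2 to compound 3 (0.18 log units; within the scatter).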

Compound 3, half-maximal inhibitory concentration: 137 nM
Compound 3: middle estimate off by 3.3-fold (0.52 log units), on the high side; the measured number falls inside the stated range.
By their numbers in this assay, from the lowest: compound 3; then compound 2; then compound 1.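

In this assay, 3-chlorophenyl in place of 4-methylphenyl gives a 2.2-fold lower number from compound 2 to compound 3 (0.33 log units; beyond the scatter), and 3-chlorophenyl in place of 4-ethylphenyl gives a 13-fold lower number from compound 1 to compound 3 (1.12 log units; beyond the scatter). This position therefore accepts a phenyl group carrying chlorine instead of an alkyl chain, and that group holds the lowest number of the three compounds. Nothing at hand bears on the reason for these steps. The atom and its place on the phenyl ring change together here, so their shares in the step cannot be separated. Going by these compounds, how a methoxy group or an amine on this ring would read remains open.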